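The source may report more compounds than this note shows. Statements on the series, on what has been measured and on what is new or still open speak of the compounds shown alone.

Compound 1, `O=S(=O)(Nc1ccc2oc(-c3ccccc3)nc2c1)c1cccc(C(F)(F)F)c1`, in an ADME assay on HEK293 cells (Homo sapiens) for cytotoxicity, read by resazurin assay, with a stated time of 48 h (on this read-out lower numbers stand for higher toxicity in this test and higher numbers for lower toxicity in this test), gives > 100000 nM, which is a limit of the assay and not a number.
Compound 2, `O=S(=O)(Nc1ccc2oc(-c3ccccc3)nc2c1)c1cccc(Cl)c1`, in this assay gives 70000 nM.

Compound 2 thus holds the only number shown in this assay; the one further value is a limit. For the measured compounds named here, the single measured step, an at least 1.4-fold lower number from compound 1 to compound 2 (0.15 log units; that floor lies within the scatter), exchanges chloro for trifluoromethyl on an aromatic carbon, and because of the limit of > 100000 nM in this assay, at which 1 of the 2 values shown sits, its size is known only as a floor that lies within the scatter.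

Compound 3, `CCc1ccc(S(=O)(=O)Nc2ccc3oc(-c4ccccc4)nc3c2)cc1`, differs from compound 2 by 4-ethylphenyl in place of 3-chlorophenyl on a sulfonyl sulfur. No measured step touches the group on the sulfonyl sulfur, and the one step shown, an at least 1.4-fold lower number from compound 1 to compound 2 (0.15 log units; that floor lies within the scatter), gives no direction beyond the scatter. Compound 3 is therefore expected to stay close to compound 2, with an estimated step of no change at the digits printed from compound 2 to compound 3 (within the scatter). For compound 3 the estimate in this assay is 70000 nM, expected to fall between 25000 nM and 200000 nM.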

Compound 3, half-maximal cytotoxic concentration: 81000 nM
Beside the measured number, compound 3's estimate is 1.2-fold (0.06 log units) below it, within the range that was stated.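

Setting 4-ethylphenyl in place of 3-chlorophenyl on the sulfonyl sulfur gives in this assay a 1.2-fold higher number from compound 2 to compound 3 (0.06 log units; within the scatter) and is the first measured step at this position, since the one earlier step exchanged only a single group on an aromatic carbon. For this one pair, the whole group on the sulfonyl sulfur changes, chlorine leaving and an ethyl group entering, without a difference that stands out from the scatter. Nothing measured here bears on a cause for this result.

The compounds shown leave open whether an amine or a carboxylic acid on this aromatic ring, or a longer chain in place of ethyl, would move the number beyond the scatter. They also leave open how the same exchange would read on other groups around the shared core.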